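This account rests on a few compounds, and the source may have more. Where it says the series, first, only, none or still open, it means among the compounds named here.

The compounds share one core, shown in compound 1 `O=C(O)[C@@H]1CCCN1C(=O)CN(c1nc(Cl)nc2[nH]cnc12)C1CC1`, where a 2-carboxypyrrolidin-1-yl group sits on the carbonyl carbon. In a functional assay on the whole organism (Tail, strain ICR) with Mus musculus as the target, in the tail flick test, with a stated time of 90 min, at a dose of 25 umol/kg by the oral route (on this read-out higher numbers stand for a stronger effect at the one dose given and lower numbers for a weaker effect), compound 1 gives 26%. Compound 2 `O=C(O)CC[C@H](NC(=O)CN(c1nc(Cl)nc2[nH]cnc12)C1CC1)C(=O)O` gives 44.7% in this assay, and compound 3 `C[C@@H](O)[C@H](NC(=O)CN(c1nc(Cl)nc2[nH]cnc12)C1CC1)C(=O)O` gives 35.9%. The number for compound 3 lies between the other two, and both gaps fall within the scatter: a number 9.9 percentage points higher from compound 1 to compound 3 (within the scatter), and a number 8.8 percentage points lower from compound 2 to compound 3 (within the scatter). Neither replacement of the group on the carbonyl carbon, nor the swap of side chains at the saturated chain carbon bound to an amide-type nitrogen and a carbonyl carbon, has shifted the read-out beyond the scatter.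

Compound 4 `CSCC[C@H](NC(=O)CN(c1nc(Cl)nc2[nH]cnc12)C1CC1)C(=O)O` differs from compound 3 at that same saturated chain carbon: 2-(methylsulfanyl)ethyl in place of 1-hydroxyethyl on a saturated chain carbon bound to an amide-type nitrogen and a carbonyl carbon. For the measured compounds named here, the only measured step that bears on this change is the one from compound 2 to compound 3, a swap at the same place that stayed within the scatter. Going by the values given here, nothing among the measured compounds indicates that a side-chain change at this position moves this assay beyond its scatter, so no step beyond the scatter is expected in this assay; the expected step is a number 1.1 percentage points higher from compound 3 to compound 4 (within the scatter). Compound 4 is therefore estimated at 37%, within a range from 22% to 52%.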

Compound 4, a percentage reported as activity, at one dose (the size of the read-out at that dose, not a potency): 14%
For compound 4 the middle estimate is 23 percentage points above the measured one; measured number outside the range, below it.
By their numbers in this assay, from the lowest: compound 4; then compounds 1, 3 and 2 (each within the scatter of the next, the first and the last beyond it).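

At the saturated chain carbon bound to an amide-type nitrogen and a carbonyl carbon, the side chain does make a difference in this assay (2-(methylsulfanyl)ethyl in place of 1-hydroxyethyl: a number 21.9 percentage points lower from compound 3 to compound 4 (beyond the scatter)). The gap widens when the methylsulfanyl end is set against the carboxy end of the otherwise matching chain (a number 30.7 percentage points lower from compound 2 to compound 4 (beyond the scatter)), whereas the swap at this place that was known before stayed small (a number 8.8 percentage points lower from compound 2 to compound 3 (within the scatter)), so this position is sensitive to some side chains and not to all. No measurement at hand accounts for the drop with the 2-(methylsulfanyl)ethyl group, so it stands as an observation without an explanation.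

The compounds shown leave open whether the sulfur atom or the chain as a whole goes with the lower number; a plain propyl chain, a chain ending in an amine, or a longer chain ending in a carboxylic acid at this place would help to separate these. They also leave open whether the same order would hold at other doses or other times.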